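The source may report more compounds than this note shows. Statements on the series, on what has been measured and on what is new or still open speak of the compounds shown alone.

Measured so far:
compound 1 `Cc1cccc(Nc2nc(N)nc(COc3ccc4c(C)cc(=O)oc4c3)n2)c1`: 1780 nM
compound 2 `Cc1cc(=O)oc2cc(OCc3nc(N)nc(Nc4cccc(Cl)c4)n3)ccc12`: 1110 nM
compound 3 `Cc1cc(Nc2nc(N)nc(COc3ccc4c(C)cc(=O)oc4c3)n2)ccc1Cl`: 240 nM

In an assay on COS-7 cells for agonist activity at Free fatty acid receptor 1 (Homo sapiens), read by scintillation counting and inositol phosphate accumulation, with a stated time of 90 min (a higher number here means that more compound is needed for the effect, a lower number that less compound is needed), compound 3 stands lowest of the three, with a 4.6-fold lower number from compound 2 to compound 3 (0.67 log units; beyond the scatter) and a 7.4-fold lower number from compound 1 to compound 3 (0.87 log units; beyond the scatter) both beyond the scatter. Compound 4 `CCc1ccc(Nc2nc(N)nc(COc3ccc4c(C)cc(=O)oc4c3)n2)cc1Cl` differs from compound 3 by 3-chloro-4-ethylphenyl in place of 4-chloro-3-methylphenyl on a nitrogen on an aromatic ring. Going by the values given here, no measured step covers this exchange; the steps of a 1.6-fold lower number from compound 1 to compound 2 (0.21 log units; within the scatter) (within the scatter) and a 7.4-fold lower number from compound 1 to compound 3 (0.87 log units; beyond the scatter) show that ring substitution on the anilino group can shift the number modestly, but nothing here tells the direction for this swap. A small step in either direction, likely within the scatter, is expected, a 1.7-fold higher number from compound 3 to compound 4 (0.22 log units; within the scatter). Compound 4 is therefore estimated at 400 nM, with a range of 150 nM to 1100 nM.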

Compound 4, half-maximal effective concentration: 160 nM
Estimate against measurement, compound 4: 2.5-fold (0.40 log units) above; measured number inside the range.
By their numbers in this assay, from the lowest: compounds 4 and 3 (each within the scatter of the next); then compounds 2 and 1 (each within the scatter of the next).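

In this assay, 3-chloro-4-ethylphenyl in place of 4-chloro-3-methylphenyl on the nitrogen gives a 1.5-fold lower number from compound 3 to compound 4 (0.18 log units; within the scatter) and so does not separate the two groups. An added ethyl group gives a 6.9-fold lower number from compound 2 to compound 4 (0.84 log units; beyond the scatter) and shows that this position accepts a chain of two carbons. Going by these compounds alone, the full exchange from 3-methylphenyl gives an 11-fold lower number from compound 1 to compound 4 (1.05 log units; beyond the scatter) and is the first large step. Open, as far as these compounds go, is whether a propyl chain or a methoxy group in place of the ethyl would hold this level. No measured evidence bears on the reason for these steps.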